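A few compounds are considered here, and "the series" means these few. Any claim that something is new, unique, unknown or untested is made for them only; others in the source may bear on it.

In a functional assay on HepG2 cells (Homo sapiens) for antiproliferative activity, read by XTT assay, with a stated time of 72 h (on this read-out lower numbers stand for stronger inhibition and higher numbers for weaker inhibition), compound 2 `Cc1ncnc2c1c(-c1cc3ccccc3o1)cn2[C@@H]1O[C@H](CO)[C@@H](O)[C@H]1O` reaches only a limit, > 20000 nM. Compound 1 `Cc1ncnc2c1c(-c1cccs1)cn2[C@@H]1O[C@H](CO)[C@@H](O)[C@H]1O` also reaches only a limit, > 15000 nM. Among the compounds with values here, the only measured change that bears on what follows is a step that the two limits leave unreadable from compound 1 to compound 2, and it offers no size to carry forward. The change to compound 3 `C#Cc1cn([C@@H]2O[C@H](CO)[C@@H](O)[C@H]2O)c2ncnc(C)c12` is ethynyl in place of 1-benzofuran-2-yl on an aromatic carbon. Compound 2 stands at the limit > 20000 nM, so any expected change can only run toward stronger inhibition, by an uncertain amount. The expected step is an at least 3.3-fold lower number from compound 2 to compound 3 (0.52 log units; beyond the scatter). For compound 3 the estimated value is 6000 nM, with an expected range from 500 nM to 40000 nM.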

Compound 3, half-maximal inhibitory concentration: 290 nM
Beside the measured number, compound 3's estimate is 21-fold (1.32 log units) above it; the measured number lies below the stated range.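

In this assay, the ring-bearing groups of compound 1 and compound 2 gave only limits, so the step between them cannot be read and this carbon showed no measurable activity. Ethynyl, which has no ring, changes that: it gives an at least 68-fold lower number from compound 2 to compound 3 (1.83 log units; beyond the scatter) and an at least 51-fold lower number from compound 1 to compound 3 (1.71 log units; beyond the scatter). Both steps are large, and they show that this position can carry activity in the micromolar-or-better range only once the aromatic rings are gone.

The compounds shown leave open whether the gain depends on the triple bond itself or only on the absence of a ring at this carbon. An ethyl group, a nitrile or an amine there would speak to that.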